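A Second Chloro Group on a Shared Core

The source may hold more compounds than are shown below. What is called first, only, known or untested is meant among the compounds shown, and "the series" means these compounds.

Compound 1 `ClCc1cccc(Cn2cnc3ncnc(Cl)c32)c1` and compound 2 `ClCc1ccccc1Cn1cnc2ncnc(Cl)c21` are built from the same atoms joined differently; the difference between the two cores is not broken down here. In a functional assay on CCRF-CEM cells (Homo sapiens) for cytotoxicity, read by sulforhodamine B assay, with a stated time of 48 h (a lower number here means a stronger inhibitor of growth, a higher number a weaker inhibitor of growth), compound 1 gives 6910 nM, and compound 2 gives 1440 nM. Compound 3 `ClCc1cccc(Cn2cnc3nc(Cl)nc(Cl)c32)c1` is compound 1 carrying (chloro in place of hydrogen on an aromatic carbon); compound 3 gives 1380 nM, which is a 5.0-fold lower number from compound 1 to compound 3 (0.70 log units; beyond the scatter). Compound 4 `ClCc1ccccc1Cn1cnc2nc(Cl)nc(Cl)c21` is compound 2 carrying (chloro in place of hydrogen on an aromatic carbon), the same change at the same kind of place. Among the compounds with values here, a step of similar size is expected from compound 2 to compound 4, a 4.1-fold lower number from compound 2 to compound 4 (0.61 log units; beyond the scatter), because a 5.0-fold lower number from compound 1 to compound 3 (0.70 log units; beyond the scatter) is the only example of this change yet measured. Compound 4 is therefore estimated at 350 nM, expected to lie between 120 nM and 1000 nM.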

Compound 4, concentration for 50% growth inhibition: 100 nM
Beside the measured number, compound 4's estimate is 3.5-fold (0.54 log units) above it; measured number outside the range, below it.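

In this assay, placing a chloro group on the core of compound 2 gives a 14-fold lower number from compound 2 to compound 4 (1.16 log units; beyond the scatter), so the same change lowers the number on both cores, but by clearly different amounts: the same change on two cores in this assay, a 5.0-fold lower number (0.70 log units; beyond the scatter) from compound 1 to compound 3 and a 14-fold lower number (1.16 log units; beyond the scatter) from compound 2 to compound 4, 2.9-fold (0.46 log units) apart, beyond the scatter of two such steps

The direction of the step carried over from one core to the other, but its size did not, so a step measured on one core served here as a guide to direction and not to extent. Two pairs cannot show why the size differs, or whether the direction would hold on any further core.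

The compounds shown leave open how an amine or a methoxy group would compare with chloro on the aromatic carbon between two ring nitrogen atoms, on either core.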